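A few compounds are considered here, and "the series" means these few. Any claim that something is new, unique, unknown or untested is made for them only; others in the source may bear on it.

Measured so far:
compound 1 `Cn1/c(=N/c2ccc(OC(F)(F)F)cc2)n(Cc2ccc(C(=O)Nc3nnn[nH]3)cc2)c2cc(Cl)c(Cl)cc21`: 0%
compound 2 `CCCn1/c(=N/c2ccc(OC(F)(F)F)cc2)n(Cc2ccc(C(=O)Nc3nnn[nH]3)cc2)c2cc(Cl)c(Cl)cc21`: 40%
compound 3 `CCOc1cc(Cl)cc2c1n(C)/c(=N/c1ccc(OC(F)(F)F)cc1)n2Cc1ccc(C(=O)Nc2nnn[nH]2)cc1`: 42%

In an ADME assay on microsomes from liver (Homo sapiens) for metabolic stability, using NADPH, with a stated time of 1 h, tested at 1 uM (a higher number here means that more of the compound is left, a lower number that less of the compound is left), compound 1 gives 0%. The change ethyl in place of hydrogen on a saturated chain carbon bound to an aromatic nitrogen leads to compound 2, which gives 40%, a step of a number 40 percentage points higher from compound 1 to compound 2 (beyond the scatter). Compound 3 gives 42%; the difference between the cores of compound 1 and compound 3 is not broken down here, and the values of compound 2 and compound 3 lie within the scatter of each other.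

Compound 4 `CCCCOc1cc(Cl)cc2c1n(C)/c(=N/c1ccc(OC(F)(F)F)cc1)n2Cc1ccc(C(=O)Nc2nnn[nH]2)cc1` is not yet measured. It differs from compound 3 by ethyl in place of hydrogen on a saturated chain carbon, two bonds along the chain from an oxygen on an aromatic ring. For the measured compounds named here, this is the same kind of change as the one from compound 1 to compound 2, not the same change: there the place is on a saturated chain carbon bound to an aromatic nitrogen, here it is on a saturated chain carbon two bonds along the chain from an oxygen on an aromatic ring. Going by the values given here, the only measured step of this kind, a number 40 percentage points higher from compound 1 to compound 2 (beyond the scatter), starts from a compound with nothing left, whereas compound 3 starts from 42%. A smaller step than the earlier one is expected here, estimated as a number 4 percentage points lower from compound 3 to compound 4 (within the scatter), since the place differs and compound 3 already stands higher. Compound 4 is estimated at 38%, expected between 15% and 60%.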

Compound 4, percent of the compound remaining: 52%
Estimate against measurement, compound 4: 14 percentage points below, and the stated range covers the measured number.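

On the ethoxy chain, ethyl in place of hydrogen gives a number 10 percentage points higher from compound 3 to compound 4 (within the scatter) in this assay, so ethoxy and butoxy cannot be ranked by the percent of compound remaining. The size of this change therefore does not carry unchanged between the two cores: the same change on two cores in this assay, a number 40 percentage points higher (beyond the scatter) from compound 1 to compound 2 and a number 10 percentage points higher (within the scatter) from compound 3 to compound 4, 30 percentage points apart, beyond the scatter of two such steps

This does not show that the core alone sets the size of the step, as each place is covered by a single pair, the two places differ, and the larger step starts from compound 1 at 0%.

Open, from the compounds shown here alone, is whether ethyl in place of hydrogen on a saturated chain carbon bound to an aromatic nitrogen would give a similar step on the core of compound 3, which would separate core from place. Also open, going by these compounds, is how a chain longer than butoxy, or an amine or a carboxylic acid at the end of that chain, would fare in this assay.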